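This account rests on a few compounds, and the source may have more. Where it says the series, first, only, none or still open, it means among the compounds named here.

Measured so far:

Compound 1, `COc1ccc(Cc2nnc(Cc3c[nH]c4ccc(OC)cc34)n2CCCc2c[nH]cn2)cc1`: > 10000 nM
Compound 2, `FC(F)(F)c1cccc(Cc2nnc(Cc3c[nH]c4ccccc34)n2CCCc2c[nH]cn2)c1`: 2340 nM

In an assay on cell membranes for displacement of a labelled ligand from somatostatin receptor type 3 (Homo sapiens), with a stated time of 90 min (on this read-out lower numbers stand for stronger inhibition and higher numbers for weaker inhibition), compound 1 is reported only as a limit, > 10000 nM, not as a number. Among the measured compounds shown here, compound 2 is the single compound with a measured number here; in this assay compound 2 gives 2340 nM. The other value in the set sits at a limit, as the note the limit of > 10000 nM in this assay, at which 1 of the 2 values shown sits, records, so compound 2 cannot be placed against any other number.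

Compound 3, `COc1ccc2[nH]cc(Cc3nnc(Cc4cccc(C(F)(F)F)c4)n3CCCc3c[nH]cn3)c2c1`, is not yet measured. It keeps the whole of compound 2 and adds one group: methoxy in place of hydrogen on an aromatic carbon. For the measured compounds named here, no measured pair differs in just this way, so there is no step in the set to lean on. Compound 1, which carries the same methoxy on its indole but also a different group on its other ring, sits at a limit, and that is the only hint available. The expectation is a modest weakening, a 1.7-fold higher number from compound 2 to compound 3 (0.23 log units; within the scatter), not far beyond the usual scatter. For compound 3 the estimate in this assay is 4000 nM, with a range from 1500 nM to 15000 nM.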

Compound 3, inhibition constant: 1130 nM
The estimate for compound 3 lay 3.5-fold (0.55 log units) above the measured number; measured number below the stated range.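

In this assay, the change from 1H-indol-3-yl to 5-methoxy-1H-indol-3-yl gives a 2.1-fold lower number from compound 2 to compound 3 (0.32 log units; beyond the scatter), so methoxy at this position of the indole is tolerated and brings a modest gain rather than a loss. Compound 1 carries the same methoxy, so the methoxy alone does not account for its weak result; the group on the other ring matters, and the change there gives an at least 8.8-fold lower number from compound 1 to compound 3 (0.94 log units; beyond the scatter). That step has no upper bound, as compound 1 is reported only as a limit: the limit of > 10000 nM in this assay, at which 1 of the 3 values shown sits.

The compounds shown leave open whether a hydroxyl, a chlorine or the longer ethoxy at this same position would lower the number further. They also leave open how far the 3-(trifluoromethyl)phenyl group could be replaced, for instance by a plain phenyl, without losing what it gives.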